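Swapping a Methyl for Diethoxymethyl on the Aryl Ring

The source may hold more compounds than are shown below. What is called first, only, known or untested is meant among the compounds shown, and "the series" means these compounds.

Compound 3 `CC1=C(/C=C/C(=O)/C=C/c2cccc(C)c2)C(C)(C)CCC1O` gives 4100 nM in a functional assay on LNCaP cells (Homo sapiens) for cytotoxicity, read by MTT assay, with a stated time of 72 h; on this read-out higher numbers stand for weaker inhibition and lower numbers for stronger inhibition. Within the data shown here, no measured compound has a higher number than compound 3, but compound 2 `CC1=C(/C=C/C(=O)/C=C/c2ccc(F)cc2)C(C)(C)CCC1O`, which gives 3900 nM, sits within the scatter, since a 1.1-fold higher number from compound 2 to compound 3 (0.02 log units; within the scatter). Compound 1 `CC1=C(/C=C/C(=O)/C=C/c2cccc(C(F)(F)F)c2)C(C)(C)CCC1O` gives 740 nM, and a 5.5-fold higher number from compound 1 to compound 3 (0.74 log units; beyond the scatter). Compound 4 `CCOC(OCC)c1cccc(/C=C/C(=O)/C=C/C2=C(C)C(O)CCC2(C)C)c1` carries diethoxymethyl in place of methyl on an aromatic carbon. Among the measured compounds shown here, no measured step exchanges a methyl for a diethoxymethyl; the only step at this aromatic carbon, a 5.5-fold higher number from compound 1 to compound 3 (0.74 log units; beyond the scatter), shows that a change of the group there can move the number beyond the scatter, so a direction cannot be read from the data. For compound 4 the expected step in this assay is therefore a 1.4-fold lower number from compound 3 to compound 4 (0.14 log units; within the scatter). Compound 4 is estimated at 3000 nM, between 900 nM and 10000 nM.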

Compound 4, half-maximal inhibitory concentration: 1800 nM
The estimate for compound 4 lay 1.7-fold (0.22 log units) above the measured number; the measured number falls inside the stated range.
By their numbers in this assay, from the lowest: compound 1; then compound 4; then compounds 2 and 3 (each within the scatter of the next).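

In this assay, diethoxymethyl in place of methyl on this aromatic carbon gives a 2.3-fold lower number from compound 3 to compound 4 (0.36 log units; beyond the scatter), so a group of 7 heavy atoms is tolerated here and the number even moves down. Trifluoromethyl still gives the lowest number of the three groups at this carbon, as diethoxymethyl in its place gives a 2.4-fold higher number from compound 1 to compound 4 (0.39 log units; beyond the scatter). Nothing available explains this order of the groups. The compounds shown leave open how an amine or a carboxylic acid at this aromatic carbon would compare, and whether the number depends on the size of the group or on its oxygens.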